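Amide-nitrogen extension on the carbamoylmethyl side chain

This account rests on a few compounds, and the source may have more. Where it says the series, first, only, none or still open, it means among the compounds named here.

Three compounds sharing one core have numbers in a functional assay on OVCAR-8 cells (Homo sapiens) for antiproliferative activity; on this read-out lower numbers stand for stronger inhibition and higher numbers for weaker inhibition. Compound 1 `Cn1ncc(Cl)c1-c1cc(C(=O)N[C@@H]2CN[C@H](CCn3cncn3)C[C@H]2c2ccc(Cl)c(Cl)c2)oc1Cl` gives 1560 nM. Compound 2 `Cn1ncc(Cl)c1-c1cc(C(=O)N[C@@H]2CN[C@H](CC(=O)O)C[C@H]2c2ccc(Cl)c(Cl)c2)oc1Cl` gives 5120 nM. Compound 3 `Cn1ncc(Cl)c1-c1cc(C(=O)N[C@@H]2CN[C@H](CC(N)=O)C[C@H]2c2ccc(Cl)c(Cl)c2)oc1Cl` gives 1000 nM, the lowest of the three numbers; its nearest neighbour is compound 1, within the scatter, and its furthest is compound 2, beyond the scatter. The steps read a 3.3-fold higher number from compound 1 to compound 2 (0.52 log units; beyond the scatter), a 1.6-fold lower number from compound 1 to compound 3 (0.19 log units; within the scatter) and a 5.1-fold lower number from compound 2 to compound 3 (0.71 log units; beyond the scatter).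

Compound 4 `Cn1ncc(Cl)c1-c1cc(C(=O)N[C@@H]2CN[C@H](CC(=O)NCC(O)CO)C[C@H]2c2ccc(Cl)c(Cl)c2)oc1Cl` is the next member: 2,3-dihydroxypropyl in place of hydrogen on an amide-type nitrogen. Among the measured compounds shown here, no measured step alters the amide nitrogen itself. For the measured compounds named here, the step that bears most closely is a 5.1-fold lower number from compound 2 to compound 3 (0.71 log units; beyond the scatter), which changes the same carbonyl-bound group and is the only modest step beyond the scatter; the step of a 1.6-fold lower number from compound 1 to compound 3 (0.19 log units; within the scatter) shows that a different group on the same chain carbon sits within the scatter. Neither step tests a substituent on the carbamoyl nitrogen, so a step of no more than scatter size in either direction is expected for a 1.4-fold higher number from compound 3 to compound 4 (0.15 log units; within the scatter).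

Compound 4 is therefore estimated at 1400 nM in this assay, with a range from 500 nM to 4000 nM.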

Compound 4, half-maximal inhibitory concentration: 5900 nM
For compound 4 the middle estimate is 4.2-fold (0.62 log units) below the measured one; the measured number lies above the stated range.
By their numbers in this assay, from the lowest: compounds 3 and 1 (each within the scatter of the next); then compounds 2 and 4 (each within the scatter of the next).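

In this assay, among the compounds shown here, the amide nitrogen of the carbamoylmethyl side chain proves sensitive to substitution: 2,3-dihydroxypropyl in place of hydrogen gives a step beyond the scatter (a 5.9-fold higher number from compound 3 to compound 4 (0.77 log units; beyond the scatter)), the only measured change on that nitrogen. The substituted amide reads with the carboxy side chain, within the scatter (a 1.2-fold higher number from compound 2 to compound 4 (0.06 log units; within the scatter)), and stands apart from the triazolylmethyl-bearing side chain, beyond the scatter (a 3.8-fold higher number from compound 1 to compound 4 (0.58 log units; beyond the scatter)), so the gap that separated the carbamoyl group from the carboxy group does not survive this substitution. Nothing in the data shown accounts for the step.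

Going by these compounds, whether the step belongs to substitution on the nitrogen as such or to the 2,3-dihydroxypropyl group in particular stays open: a methyl group or an unbranched propyl chain on the same nitrogen would separate these two readings. Also open, on these data alone, is whether a chain ending in an amine on that nitrogen would read with compound 3 or with compound 4.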